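Swapping a basic amine for a fluorophenoxy group

This account rests on a few compounds, and the source may have more. Where it says the series, first, only, none or still open, it means among the compounds named here.

Compound 1 `COc1ccc2[nH]c(C(=O)N3CC(=O)N(Cc4ccccc4)[C@@H](CN4CCCCC4)C3)cc2c1`: 76900 nM
Compound 2 `COc1ccc2[nH]c(C(=O)N3CC(=O)N(Cc4cccc(OC)n4)[C@@H](Cc4ccccc4)C3)cc2c1`: > 30000 nM
Compound 3 `COc1cccc(CN2C(=O)CN(C(=O)c3cc4cc(OC)ccc4[nH]3)C[C@@H]2CCc2ccccc2)c1`: 4500 nM

In an ADME assay on Vero cells (Chlorocebus sabaeus) for cytotoxicity, with a stated time of 7 days (a lower number here means that less compound is tolerated, a higher number that more compound is tolerated), compound 1 gives 76900 nM, the highest of the two numbers reported. Compound 3 gives 4500 nM, a lower number, and the gap between compound 1 and compound 3 lies beyond the scatter. Compound 2 gives > 30000 nM, which is a limit of this assay and not a number. Across the set, only one compound sits at the limit of > 30000 nM in this assay, at which 1 of the 3 values shown sits.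

Compound 4 `COc1ccc2[nH]c(C(=O)N3CC(=O)N(Cc4ccccc4)[C@@H](COc4ccc(F)cc4)C3)cc2c1` has not been measured. It differs from compound 1 in one place: 4-fluorophenoxy in place of piperidin-1-yl on a saturated chain carbon bound to a saturated ring carbon. Among the measured compounds shown here, no measured pair tracks this exact change, so the expectation rests on the other compounds in this assay. A step downward from compound 1 to compound 4 of a 2.6-fold lower number from compound 1 to compound 4 (0.41 log units; beyond the scatter) is expected, because compound 3, which also lacks piperidin-1-yl, gives 4500 nM. Compound 4 is therefore estimated at 30000 nM, within a range from 8000 nM to 90000 nM.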

Compound 4, half-maximal cytotoxic concentration: 33200 nM
Compound 4: the middle estimate sits 1.1-fold (0.04 log units) below what was measured; the measured number falls inside the stated range.
By their numbers in this assay, from the lowest: compound 3; then compound 4; then compound 1.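

In this assay, replacing piperidin-1-yl with 4-fluorophenoxy on a saturated chain carbon bound to a saturated ring carbon gives a 2.3-fold lower number from compound 1 to compound 4 (0.36 log units; beyond the scatter), and this is the only comparison shown that changes a single place in the structure. It shows that a six-membered non-aromatic ring with a hetero atom can give way at this position to a six-membered aromatic ring of carbon only, joined through oxygen, with a real but limited shift in the read-out. Nothing in the data shown explains why the number moves.

The compounds shown leave open whether the fluorine or the ring itself accounts for the step. They also leave open how other groups at this position, such as a morpholine ring, a plain phenoxy group or a carboxylic acid, would compare.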